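Adding an Octyl Chain: Expected Effect on Cell Growth

This account rests on a few compounds, and the source may have more. Where it says the series, first, only, none or still open, it means among the compounds named here.

Compound 1 `CO/N=C/c1cc(OC)c2c(c1OC)C(=O)C=CC2=O` is the starting point. In a functional assay on L1210 cells (Mus musculus) for antiproliferative activity (on this read-out higher numbers stand for an effect only at larger amounts of compound and lower numbers for an effect already at smaller amounts), compound 1 gives 0.109 ug/mL. Compound 2 `CCCCCCCCCO/N=C/c1cc(OC)c2c(c1OC)C(=O)C=CC2=O` differs from it by one change, (octyl in place of hydrogen on a saturated chain carbon bound to an oxygen on an unsaturated carbon), and in this assay compound 2 gives 0.19 ug/mL; the step is a 1.7-fold higher number from compound 1 to compound 2 (0.24 log units; within the scatter). Compound 3 `CCCCCC/C(=N\OC)c1cc(OC)c2c(c1OC)C(=O)C=CC2=O` has a different core from compound 1, and the difference between the two cores is not broken down here; in this assay compound 3 gives 0.192 ug/mL. Compound 4 `CCCCCCCCCO/N=C(\CCCCCC)c1cc(OC)c2c(c1OC)C(=O)C=CC2=O` has not yet been measured. It differs from compound 3 by octyl in place of hydrogen on a saturated chain carbon bound to an oxygen on an unsaturated carbon, the same change at the same place that separates compound 1 from compound 2. A step of similar size is expected this time, a 1.6-fold higher number from compound 3 to compound 4 (0.19 log units; within the scatter), since the same change once gave a 1.7-fold higher number from compound 1 to compound 2 (0.24 log units; within the scatter). For compound 4 the expected value in this assay is 0.3 ug/mL, with a likely range from 0.12 ug/mL to 0.7 ug/mL.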

Compound 4, concentration for half-maximal effect: 1.15 ug/mL
Estimate against measurement, compound 4: 3.8-fold (0.58 log units) below; the measured number lies above the stated range.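

In this assay, octyl in place of hydrogen gives a clear rise on the core of compound 3, with a 6.0-fold higher number from compound 3 to compound 4 (0.78 log units; beyond the scatter). The same change therefore does not carry the same size of step from one core to the other: the same change on two cores in this assay, a 1.7-fold higher number (0.24 log units; within the scatter) from compound 1 to compound 2 and a 6.0-fold higher number (0.78 log units; beyond the scatter) from compound 3 to compound 4, 3.4-fold (0.54 log units) apart, beyond the scatter of two such steps. This shows that the step on the core of compound 1 was a poor guide to the step on the core of compound 3, but with one pair on each core it does not show why the two differ or what would happen on a further core.

Going by these compounds, it remains open how a butyl or a dodecyl chain at the same place would behave on these two cores. Also open, on these data alone, is whether an amine at the end of the chain would give a different step.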